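A few compounds are considered here, and "the series" means these few. Any claim that something is new, unique, unknown or untested is made for them only; others in the source may bear on it.

Compound 1, `NNC(=O)c1c(NC(=O)NS(=O)(=O)c2ccccc2)sc2c1CCCCC2`, reaches only the assay limit, > 100000 nM, in a functional assay on cells (Cancer cell lines, Homo sapiens) for inhibition, with a stated time of 48 h; a higher number here means a weaker inhibitor of growth, a lower number a stronger inhibitor of growth. Compound 2, `CN1CCN(C(=O)c2c(NC(=O)NS(=O)(=O)c3ccccc3)sc3c2CCCCC3)CC1`, gives 42300 nM. Compound 3, `CCCCNC(=O)c1c(NC(=O)NS(=O)(=O)c2ccccc2)sc2c1CCCCC2`, gives 72300 nM.

Compound 3 stands at the higher of the two measured numbers, but its nearest neighbour is compound 2, and the step of a 1.7-fold higher number from compound 2 to compound 3 (0.23 log units; within the scatter) lies within the scatter, so the two cannot be told apart. For the measured compounds named here, the value of compound 1 is a limit (the limit of > 100000 nM in this assay, at which 1 of the 3 values shown sits), and the step of an at least 1.3-fold lower number from compound 1 to compound 3 (0.14 log units; that floor lies within the scatter) says only that compound 3 is at least as strong.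

Compound 4, `CCCNC(=O)c1c(NC(=O)NS(=O)(=O)c2ccccc2)sc2c1CCCCC2`, differs from compound 3 by a single change: hydrogen in place of methyl on a saturated chain carbon, three bonds along the chain from an amide-type nitrogen. The measured steps that touch the same amide-type nitrogen, an at least 1.3-fold lower number from compound 1 to compound 3 (0.14 log units; that floor lies within the scatter) and a 1.7-fold higher number from compound 2 to compound 3 (0.23 log units; within the scatter), are small or only limits, so trimming the chain by one carbon is expected to move the number little, if at all, beyond the scatter. The step of a 1.0-fold higher number from compound 3 to compound 4 (0.02 log units; within the scatter) is therefore estimated to be essentially flat. Compound 4 is expected to give about 75000 nM, within 35000 nM to 160000 nM.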

Compound 4, concentration for 50% growth inhibition: 80300 nM
Compound 4: middle estimate off by 1.1-fold (0.03 log units), on the low side; the range from low to high includes it.
By their numbers in this assay, from the lowest: compounds 2, 3 and 4 (each within the scatter of the next). At a limit, above all of these: compound 1.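

In this assay, hydrogen in place of methyl on a saturated chain carbon, three bonds along the chain from an amide-type nitrogen, gives the step of a 1.1-fold higher number from compound 3 to compound 4 (0.05 log units; within the scatter), so the butyl and propyl chains cannot be told apart here. The propyl amide also cannot be told apart from the 4-methylpiperazin-1-yl amide, with a 1.9-fold higher number from compound 2 to compound 4 (0.28 log units; within the scatter), so neither the chain length nor the swap to this ring separates compounds 2, 3 and 4 in this assay. The step of an at least 1.2-fold lower number from compound 1 to compound 4 (0.09 log units; that floor lies within the scatter) cannot be read, as it rests on a limit of the assay: the limit of > 100000 nM in this assay, at which 1 of the 4 values shown sits.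

Still open, from the compounds shown here alone, is whether an octyl chain, or a chain carrying an amine or a carboxylic acid, would give a number beyond the scatter of these three compounds.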